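The source may report more compounds than this note shows. Statements on the series, on what has been measured and on what is new or still open speak of the compounds shown alone.

Compound 1 `CC(C)c1ccc(-c2nc(SCc3cn(CC(=O)NC(=O)Nc4ccccn4)nn3)nc(Nc3cccc(Cl)c3)c2C#N)cc1`: > 64000 nM
Compound 2 `CC(C)c1ccc(-c2nc(SCc3cn(CC(=O)NC(=O)Nc4ccccn4)nn3)nc(Nc3cccc(C(F)(F)F)c3)c2C#N)cc1`: > 64000 nM
Compound 3 `CC(C)c1ccc(-c2nc(SCc3cn(CC(=O)NC(=O)Nc4ccccn4)nn3)nc(Nc3cccc([N+](=O)[O-])c3)c2C#N)cc1`: > 64000 nM

In a functional assay on MGC-803 cells (Homo sapiens) for inhibition, read by MTT assay, with a stated time of 72 h (on this read-out lower numbers stand for stronger inhibition and higher numbers for weaker inhibition), compound 3 gives > 64000 nM, which is a limit of the assay rather than a number. Compound 1 gives > 64000 nM in this assay, again a limit. Compound 2 gives > 64000 nM in this assay, once more a limit. All three values therefore sit at the limit of > 64000 nM in this assay, at which 3 of the 3 values shown sit, and none of the three can be ranked against the others. The steps among them, a step that the two limits leave unreadable from compound 1 to compound 2, a step that the two limits leave unreadable from compound 1 to compound 3 and a step that the two limits leave unreadable from compound 2 to compound 3, are accordingly of unknown size and direction.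

Compound 4 `Cc1ccc(Nc2nc(SCc3cn(CC(=O)NC(=O)Nc4ccccn4)nn3)nc(-c3ccc(C(C)C)cc3)c2C#N)cc1` differs from compound 3 by 4-methylphenyl in place of 3-nitrophenyl on a nitrogen on an aromatic ring. Within the data shown here, none of the measured steps changes the same position, since each of them swaps one group for another at that position while both ends stay at the limit, and all three are unreadable; so no measured step gives a readable size for the change from compound 3 to compound 4. With the three nearest values all at the limit, compound 4 is expected to remain weak in this assay, so the expected step that the limit leaves unreadable from compound 3 to compound 4 is small or none beyond the scatter. Compound 4 is therefore estimated at 80000 nM in this assay, within a range from 20000 nM to 300000 nM.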

Compound 4, half-maximal inhibitory concentration: 3360 nM
Compound 4: middle estimate off by 24-fold (1.38 log units), on the high side; the whole stated range lies above it.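

In this assay, the (substituted phenyl)amino position on the shared core can clearly move the read-out, which compound 1, compound 2 and compound 3 could not show while all three stayed at the assay limit: 4-methylphenyl gives an at least 19-fold lower number from compound 3 to compound 4 (1.27 log units; beyond the scatter), and likewise an at least 19-fold lower number from compound 2 to compound 4 (1.27 log units; beyond the scatter) and an at least 19-fold lower number from compound 1 to compound 4 (1.27 log units; beyond the scatter). The three steps among compound 1, compound 2 and compound 3 still cannot be read, so 3-nitrophenyl, 3-(trifluoromethyl)phenyl and 3-chlorophenyl cannot be ranked against one another. Compound 4 is the only one of the four with a number rather than a limit, and the other three mark the edge of what can be compared: the limit of > 64000 nM in this assay, at which 3 of the 4 values shown sit.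

The names 4-methylphenyl and 3-nitrophenyl, 3-(trifluoromethyl)phenyl or 3-chlorophenyl differ both in the group carried and in its number on the ring, so the compounds shown do not tell which of the two goes with the step. They also leave open how a phenyl with no substituent, or a phenyl carrying a methoxy or an amine, would read in this assay.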